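The source may report more compounds than this note shows. Statements on the series, on what has been measured and on what is new or still open speak of the compounds shown alone.

Measured so far in an ADME assay on L929 cells (Mus musculus) for cytotoxicity, read by resazurin assay, with a stated time of 72 h; a higher number here means a weaker inhibitor, a lower number a stronger inhibitor:
Compound 1 `O=C(/C=C/c1ccc2c(c1)B(O)OC2)c1ccccc1`: > 10 ug/mL
Compound 2 `O=C(/C=C/c1ccc2c(c1)B(O)OC2)c1ccc(O)c(O)c1`: > 10 ug/mL
Compound 3 `O=C(/C=C/c1ccc2c(c1)B(O)OC2)c1ccc([N+](=O)[O-])cc1`: > 10 ug/mL

Each of these readings is a limit of the assay and not a number. Compound 3 therefore has no exact position, only its limit of > 10 ug/mL. It shares that position with the rest of the set: the limit of > 10 ug/mL in this assay, at which 3 of the 3 values shown sit.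

Compound 4 `O=C(/C=C/c1ccc2c(c1)B(O)OC2)c1ccc(O)cc1` has not yet been measured. It differs from compound 3 by one change: hydroxy in place of nitro on an aromatic carbon. In words, this is hydroxy in place of nitro on an aromatic carbon.

Within the data shown here, the only measured step at this place is a step that the two limits leave unreadable from compound 1 to compound 3, where nitro replaces hydrogen. Its size cannot be read, as both ends are limits. Compound 2 also carries hydroxy, and its reading of > 10 ug/mL is again a limit.

No shift beyond the scatter is expected in this assay, in either direction, so the expected step is a step that the limit leaves unreadable from compound 3 to compound 4. Compound 4 is estimated at 20 ug/mL, with an expected range from 9 ug/mL to 60 ug/mL.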

Compound 4, half-maximal inhibitory concentration: > 10 ug/mL
Compound 4 gave a limit, no number (the forecaster's own chance of this, stated with the estimate: 85%); the middle value lies beyond the limit too.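

In this assay, among these compounds, compound 4 gives another limit, so no step linking it to compound 1, compound 2 or compound 3 can be read, because every reading is a limit: the limit of > 10 ug/mL in this assay, at which 4 of the 4 values shown sit. The compounds shown leave open whether hydroxy, nitro or hydrogen on this aromatic carbon makes any difference to cytotoxicity.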